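Aryl change on the shared core: compound 2 to 3

A few compounds are considered here, and "the series" means these few. Any claim that something is new, unique, unknown or untested is made for them only; others in the source may bear on it.

Compound 1 `COc1cc(-c2ncncc2-c2ccc(C(N)=O)cc2)cc(OC)c1OC`: > 100000 nM (a limit)
Compound 2 `COc1cc(-c2ncncc2-c2ccc(Br)cc2)cc(OC)c1OC`: 2960 nM
Compound 3 `COc1cc(-c2ncncc2-c2ccc3cc[nH]c3c2)cc(OC)c1OC`: not yet measured

Among the measured compounds shown here, in a functional assay on SiHa cells (Homo sapiens) for antiproliferative activity, read by CCK-8 assay, with a stated time of 72 h (on this read-out lower numbers stand for stronger inhibition and higher numbers for weaker inhibition), compound 2 gives 2960 nM, the only actual number so far. Compound 1 stands at > 100000 nM, which is a limit of this assay. Compound 3 carries 1H-indol-6-yl in place of the 4-bromophenyl of compound 2 (1H-indol-6-yl in place of 4-bromophenyl on an aromatic carbon). For the measured compounds named here, one measured step bears on this: an at least 33-fold lower number from compound 1 to compound 2 (1.52 log units; beyond the scatter). It is large, beyond the scatter, and falls on the phenyl group that now leaves. That single step shows a strong response to change on this group but fixes no direction for the incoming group, so only a moderate move towards a lower number in this assay is expected, with wide uncertainty. The expected change is a 3.7-fold lower number from compound 2 to compound 3 (0.57 log units; beyond the scatter). For compound 3 the estimated value is 800 nM, with an expected range of 50 nM to 10000 nM.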

Compound 3, half-maximal inhibitory concentration: 2180 nM
For compound 3 the middle estimate is 2.7-fold (0.44 log units) below the measured one; measured number inside the range.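

In this assay, with a 1.4-fold lower number from compound 2 to compound 3 (0.13 log units; within the scatter), 1H-indol-6-yl and 4-bromophenyl cannot be told apart on this aromatic carbon, so this position accepts two quite different aryl groups, one of them carrying a hydrogen-bond donor. The second large step, an at least 45-fold lower number from compound 1 to compound 3 (1.66 log units; beyond the scatter), repeats the gap first seen with the bromo group, which leaves 4-carbamoylphenyl alone at the weak end among the three groups shown. The true size of both gaps from compound 1 stays unknown because that compound is held at a limit: the limit of > 100000 nM in this assay, at which 1 of the 3 values shown sits.

As far as these compounds go, whether the indole hydrogen on nitrogen plays any part stays open, and a 1-methyl-1H-indol-6-yl group would speak to that. Also open, from the compounds shown here alone, is how a smaller substituent such as fluoro, or an amine or a carboxylic acid on the phenyl ring, would read here.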